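The source may hold more compounds than are shown below. What is called first, only, known or untested is meant among the compounds shown, and "the series" means these compounds.

- Compound 1 `COc1ccc2[nH]cc(/C=C(\C#N)C(=O)c3c[nH]c4ccccc34)c2c1` gives 13700 nM in a functional assay on A549 cells (Homo sapiens) for cytotoxicity, read by WST assay, with a stated time of 48 h; a higher number here means a weaker inhibitor, a lower number a stronger inhibitor
- Compound 2 `N#C/C(=C\c1c[nH]c2cc(F)ccc12)C(=O)c1c[nH]c2ccccc12` gives 22700 nM in this assay
- Compound 3 `COc1ccc2c(/C=C(\C#N)C(=O)c3c[nH]c4ccccc34)c[nH]c2c1` gives 5800 nM in this assay

Of these three, compound 3 has the lowest number, so it is the strongest inhibitor measured so far. In compound 4 `N#C/C(=C\c1c[nH]c2ccccc12)C(=O)c1c[nH]c2ccccc12`, hydrogen stands in place of methoxy on an aromatic carbon (hydrogen in place of methoxy on an aromatic carbon). The closest measured step, methoxy in place of fluoro on an aromatic carbon, gives a 3.9-fold lower number from compound 2 to compound 3 (0.59 log units; beyond the scatter) and is modest. It concerns the same carbon, but it starts from fluoro, not hydrogen, so it is only indirect evidence. Compound 1, with its methoxy elsewhere on the shared core, gives 13700 nM and so also sits higher than compound 3. Among the compounds with values here, no compound lacking a group on that ring has been measured yet. Losing the methoxy is therefore expected to raise the number modestly, toward compound 1 and compound 2. The expected size in this assay is a 2.6-fold higher number from compound 3 to compound 4 (0.41 log units; beyond the scatter) and remains uncertain. The estimated value for compound 4 is 15000 nM (expected range 6500 nM to 35000 nM).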

Compound 4, half-maximal inhibitory concentration: 22000 nM
Beside the measured number, compound 4's estimate is 1.5-fold (0.17 log units) below it, and the stated range covers the measured number.
By their numbers in this assay, from the lowest: compound 3; then compounds 1, 4 and 2 (each within the scatter of the next).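

In this assay methoxy can now be compared directly with hydrogen at this carbon, and the step of a 3.8-fold higher number from compound 3 to compound 4 (0.58 log units; beyond the scatter) shows that the methoxy itself goes with the lower number, not just any group at this place. Fluoro on the same carbon does not do this, since the step of a 1.0-fold lower number from compound 2 to compound 4 (0.01 log units; within the scatter) leaves it level with hydrogen. A methoxy elsewhere on the shared core, as in compound 1, is not separated from hydrogen either, with a step of a 1.6-fold higher number from compound 1 to compound 4 (0.21 log units; within the scatter) that ties the lower number to this one place among the compounds shown.

On these data alone, whether an ethoxy, a hydroxyl or an amine on this carbon would match the methoxy remains open. Nothing available gives a reason why methoxy differs from hydrogen here.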